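Thiophen-3-yl Gives Way to Chloro on the Shared Core

The compounds below may be only part of what the source reports. "The series", "measured", "known", "first", "only" and "open" are said of these compounds alone.

- Compound 1 (`CC(C)(O)c1cc2c(-c3ccc(C#N)cc3)nccc2[nH]1`) gives "not determined" (no result reported)
- Compound 2 (`CC(C)(O)c1cc2c(-c3ccccc3CO)nccc2[nH]1`) gives "not determined" (no result reported)
- Compound 3 (`CC(C)(O)c1cc2c(-c3ccsc3)nccc2[nH]1`) gives 199000 nM

In an ADME assay on U2OS cells (Homo sapiens) for cytotoxicity (on this read-out lower numbers stand for higher toxicity in this test and higher numbers for lower toxicity in this test), compound 3 stands alone with a number, at 199000 nM, while neither of the other two compounds has a result to compare with it. Compound 4 (`CC(C)(O)c1cc2c(Cl)nccc2[nH]1`) carries chloro in place of thiophen-3-yl on an aromatic carbon, next to the ring nitrogen: chloro in place of thiophen-3-yl on an aromatic carbon. Going by the values given here, no measured pair shows what such a change does. With only compound 3 at 199000 nM as an anchor, no step beyond the scatter is expected in this assay. The estimated step is a 1.3-fold lower number from compound 3 to compound 4 (0.12 log units; within the scatter). For compound 4 the expected value is 150000 nM, with an estimated range from 60000 nM to 350000 nM.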

Compound 4, half-maximal cytotoxic concentration: 15500 nM
Beside the measured number, compound 4's estimate is 9.7-fold (0.99 log units) above it; the measured number lies below the stated range.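

Chloro in place of thiophen-3-yl on this aromatic carbon, next to the ring nitrogen, brings a 13-fold lower number from compound 3 to compound 4 (1.11 log units; beyond the scatter) in this assay and so gives the first measured sign that this position can move the read-out. The number shifts toward higher toxicity in this test when a single chlorine atom replaces the five-membered aromatic ring. No measurement at hand accounts for this step.

Steps involving compound 1 and compound 2 cannot be read. Going by these compounds, whether an amine or a methoxy group here would give a number closer to compound 3 or to compound 4 remains open.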